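The source may hold more compounds than are shown below. What is called first, only, known or untested is meant among the compounds shown, and "the series" means these compounds.

Measured so far:
Compound 1 `CCCc1nc(-c2ccccc2)c(CNCCN2CCN(c3ccccc3Cl)CC2)o1` — 4370 nM in an assay on HEK293 cells for inhibition of Voltage-dependent T-type calcium channel subunit alpha-1G (Homo sapiens), read by patch clamp; a lower number here means a stronger inhibitor, a higher number a weaker inhibitor
Compound 2 `CCCc1nc(-c2ccccc2)c(CNCCN2CCN(c3ccc(Cl)cc3)CC2)o1` — 2820 nM in this assay
Compound 3 `CCCc1nc(-c2ccccc2)c(CNCCN2CCN(c3ccccc3C)CC2)o1` — 4300 nM in this assay

Compound 3 stands beside the other two: a 1.0-fold lower number from compound 1 to compound 3 (0.01 log units; within the scatter) and a 1.5-fold higher number from compound 2 to compound 3 (0.18 log units; within the scatter), so the three numbers cannot be told apart within the scatter. Compound 4 `CCCc1nc(-c2ccccc2)c(CNCCN2CCN(c3ccccc3C(F)(F)F)CC2)o1` differs from compound 3 by trifluoromethyl in place of methyl on an aromatic carbon. The step that bears most on this change is a 1.0-fold lower number from compound 1 to compound 3 (0.01 log units; within the scatter), where one small group gave way to another on an aromatic carbon and nothing beyond the scatter followed; a 1.5-fold lower number from compound 1 to compound 2 (0.19 log units; within the scatter) likewise moved nothing. For the measured compounds named here, with no step in this set reaching beyond the scatter, the expectation for compound 4 is a step of a 1.1-fold lower number from compound 3 to compound 4 (0.03 log units; within the scatter) in this assay, that is none beyond the scatter. Compound 4 is therefore estimated at 4000 nM, within 1500 nM to 10000 nM.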

Compound 4, half-maximal inhibitory concentration: 2100 nM
For compound 4 the middle estimate is 1.9-fold (0.28 log units) above the measured one; the measured number falls inside the stated range.
By their numbers in this assay, from the lowest: compounds 4, 2, 3 and 1 (each within the scatter of the next, the first and the last beyond it).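

In this assay, for the compounds shown here, trifluoromethyl on this aromatic carbon, ortho to a large group, gives the first steps beyond the scatter in the set, though both are modest (a 2.0-fold lower number from compound 3 to compound 4 (0.31 log units; beyond the scatter); a 2.1-fold lower number from compound 1 to compound 4 (0.32 log units; beyond the scatter)). The change from 4-chlorophenyl to 2-(trifluoromethyl)phenyl, by contrast, stays within the scatter (a 1.3-fold lower number from compound 2 to compound 4 (0.13 log units; within the scatter)). Nothing in the data shown accounts for these steps.

The compounds shown leave open what a methoxy group or a nitrile would give on this same aromatic carbon. They also leave open whether a plain phenyl, with no group there at all, would sit with these numbers.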